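The compounds below may be only part of what the source reports. "The series", "measured", "known", "first", "only" and "open" are said of these compounds alone.

Measured compounds:
compound 1 `Cc1ccccc1NC(=O)c1c(O)c2cccnc2n(-c2ccccc2)c1=O` — 11.7%
compound 2 `O=C(NCc1ccncc1)c1c(O)c2cccnc2n(-c2ccccc2)c1=O` — 10%

Both compounds were tested in a functional assay on the whole organism for inhibition, with Rattus norvegicus as the target, read by paw edema, at a dose of 100 mg/kg by the oral route; on this read-out lower numbers stand for less inhibition and higher numbers for more inhibition at the one dose given (going by the name of the read-out). In this assay compound 1 gives 11.7% and compound 2 gives 10%. For the measured compounds named here, the one step that joins them, a number 1.7 percentage points lower from compound 1 to compound 2 (within the scatter), stays within the usual scatter, so compound 2 cannot be told apart from compound 1 on these numbers; both sit low on this read-out.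

The next compound, compound 3 `O=C(Nc1ccc(Cl)nc1)c1c(O)c2cccnc2n(-c2ccccc2)c1=O`, has not yet been measured. It differs from compound 2 in one place: 6-chloropyridin-3-yl in place of (pyridin-4-yl)methyl on an amide-type nitrogen. Going by the values given here, the only measured step that bears on a swap at this amide-type nitrogen is the one from compound 1 to compound 2, and that step was small. Compound 3 again carries an aromatic ring joined directly to the amide-type nitrogen, as compound 1 does, and compound 1 and compound 2 gave much the same result. The expected step is therefore a number 2 percentage points higher from compound 2 to compound 3 (within the scatter), that is, none beyond the scatter. On this basis compound 3 is estimated at 12% in this assay, with a range from 2% to 25%.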

Compound 3, a percentage reported as inhibition, in the whole organism at one dose (the size of the read-out at that dose, not a potency): 9.2%
For compound 3 the middle estimate is 2.8 percentage points above the measured one; the measured number falls inside the stated range.
By their numbers in this assay, from the lowest: compounds 3, 2 and 1 (each within the scatter of the next).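

In this assay, 6-chloropyridin-3-yl on the amide-type nitrogen gives a number 0.8 percentage points lower from compound 2 to compound 3 (within the scatter) and, set against the 2-methylphenyl group, a number 2.5 percentage points lower from compound 1 to compound 3 (within the scatter) on the same read-out. The third compound therefore adds a new kind of group at this position, one that carries a chlorine and a ring nitrogen and has its ring joined directly to the amide-type nitrogen. All three compounds still cannot be told apart, so neither the methyl link in (pyridin-4-yl)methyl nor the chlorine separates any of them here, and all three stay low at the one dose given. Nothing available here explains this flat result.

All three groups shown at this nitrogen contain a six-membered aromatic ring, so it remains open whether a group of another type, such as a carboxylic acid, an open-chain amine or a longer carbon chain, would give a number clearly different from these. The compounds also leave open what a change elsewhere on the shared core would do, for example replacing the phenyl group that all three carry.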